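Moving a Trifluoromethyl Group on a Sulfonyl Sulfur

A few compounds are considered here, and "the series" means these few. Any claim that something is new, unique, unknown or untested is made for them only; others in the source may bear on it.

The study concerns four compounds built on the same amide-bearing core, differing in the aryl group attached to a sulfur. Compound 1 `CC(O)(CSc1cccc(C(F)(F)F)c1)C(=O)Nc1cc(C(F)(F)F)cc(C(F)(F)F)c1` carries a 3-(trifluoromethyl)phenyl on a sulfur; in a functional assay on VCaP cells (Homo sapiens) for antiproliferative activity, read by fluorescence and propidium iodide staining, with a stated time of 96 h (on this read-out higher numbers stand for weaker inhibition and lower numbers for stronger inhibition), compound 1 gives 9860 nM. Compound 2 `CC(O)(CSc1ccccc1C(F)(F)F)C(=O)Nc1cc(C(F)(F)F)cc(C(F)(F)F)c1` carries the 2-(trifluoromethyl)phenyl instead, and in this assay compound 2 gives 3840 nM. The difference between these two is 2-(trifluoromethyl)phenyl in place of 3-(trifluoromethyl)phenyl on a sulfur, and it produced a 2.6-fold lower number from compound 1 to compound 2 (0.41 log units; beyond the scatter).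

Compound 3 `CC(O)(CS(=O)(=O)c1cccc(C(F)(F)F)c1)C(=O)Nc1cc(C(F)(F)F)cc(C(F)(F)F)c1` bears the 3-(trifluoromethyl)phenyl on a sulfonyl sulfur; the difference between the core of compound 3 and the core of compound 1 is not broken down here. In this assay compound 3 gives 9980 nM, which lies within the scatter of the value of compound 1, so no order can be read between them.

Compound 4 `CC(O)(CS(=O)(=O)c1ccccc1C(F)(F)F)C(=O)Nc1cc(C(F)(F)F)cc(C(F)(F)F)c1` has not been measured. It differs from compound 3 by 2-(trifluoromethyl)phenyl in place of 3-(trifluoromethyl)phenyl on a sulfonyl sulfur. This is the same kind of change as that from compound 1 to compound 2, though not the same: in compound 1 the change sits on a sulfur whose other neighbours are a saturated chain carbon, whereas in compound 3 it sits on a sulfonyl sulfur whose other neighbours are a saturated chain carbon. The expectation for compound 4 rests on a single precedent, the step of a 2.6-fold lower number from compound 1 to compound 2 (0.41 log units; beyond the scatter), together with the closeness of compound 1 at 9860 nM and compound 3 at 9980 nM. Compound 4 is therefore expected to show a 2.2-fold lower number from compound 3 to compound 4 (0.35 log units; beyond the scatter). The estimate for compound 4 in this assay is 4500 nM, with a range from 2000 nM to 10000 nM.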

Compound 4, half-maximal inhibitory concentration: 8550 nM
Estimate against measurement, compound 4: 1.9-fold (0.28 log units) below; measured number inside the range.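

In this assay, 2-(trifluoromethyl)phenyl in place of 3-(trifluoromethyl)phenyl on a sulfonyl sulfur gives a 1.2-fold lower number from compound 3 to compound 4 (0.07 log units; within the scatter), so this exchange produces no readable change on that core, whereas the same exchange on a sulfur gave a 2.6-fold lower number from compound 1 to compound 2 (0.41 log units; beyond the scatter). Set side by side, the two steps cannot be told apart, so the series gives no firm sign that the core alters the outcome of this change: the same change on two cores in this assay, a 2.6-fold lower number (0.41 log units; beyond the scatter) from compound 1 to compound 2 and a 1.2-fold lower number (0.07 log units; within the scatter) from compound 3 to compound 4, 2.2-fold (0.34 log units) apart, within the scatter of two such steps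

What this shows is limited: the step beyond the scatter on the core of compound 1 was not reproduced as a readable step on the core of compound 3, yet the results do not show that the change fails to carry over, nor that it carries over in full, and they rest on a single pair for each core.

The compounds shown leave open how this exchange would behave with a sulfinyl group in place of the sulfur or the sulfonyl group. They also leave open whether a nitrile or a chlorine in place of the trifluoromethyl group on the aryl ring would give steps that can be read more clearly on either core.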